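Adding a Third Chlorine to the Aryl Ring of Compound 1

A few compounds are considered here, and "the series" means these few. Any claim that something is new, unique, unknown or untested is made for them only; others in the source may bear on it.

Measured compounds:
compound 1, `NC1=NC2(CCSCC2)N(OCCCOc2ccc(Cl)c(Cl)c2)C(N)=N1`: 89.8%
compound 2, `NC1=NC2(CCOCC2)N(OCCCOc2ccc(Cl)cc2)C(N)=N1`: "not determined" (no result reported)
compound 3, `Cc1cc(C)cc(OCCCON2C(N)=NC(N)=NC23CCOCC3)c1`: 88.6%

In an assay on isolated protein for inhibition of Dihydrofolate reductase (Homo sapiens), read by spectrophotometry, using NADPH, with stated times of 5 s and 6 min, tested at 50 uM (a lower number here means a weaker effect, a higher number a stronger effect of the compound at the concentration tested), compound 1 gives 89.8%, the higher of the two numbers reported. Compound 3 gives 88.6%, a value that lies within the usual scatter of that of compound 1, so the two cannot be ordered. For compound 2 no result was reported in this assay.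

Compound 4, `NC1=NC2(CCSCC2)N(OCCCOc2cc(Cl)c(Cl)cc2Cl)C(N)=N1`, differs from compound 1 by chloro in place of hydrogen on an aromatic carbon. Among the measured compounds shown here, no step between measured compounds describes such a change, so the expectation for compound 4 rests on compound 1 alone. Because compound 1 already gives 89.8%, a step from compound 1 to compound 4 of a number 1.8 percentage points lower from compound 1 to compound 4 (within the scatter) is expected, that is, none beyond the scatter. Compound 4 is therefore estimated at 88%, with a range from 72% to 96%.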

Compound 4, a percentage reported as inhibition, at one concentration (the size of the read-out at that concentration, not a potency): 94.4%
Estimate against measurement, compound 4: 6.4 percentage points below; the range from low to high includes it.
By their numbers in this assay, from the lowest: compounds 3, 1 and 4 (each within the scatter of the next).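

In this assay, chloro in place of hydrogen on an aromatic carbon ortho to a large group, which turns 3,4-dichlorophenyl into 2,4,5-trichlorophenyl, gives a number 4.6 percentage points higher from compound 1 to compound 4 (within the scatter), so this position accepts a third chlorine with no change beyond the scatter. Both read-outs come from a single concentration, so this step says nothing about potency. Nothing shown gives a cause for the step. From the compounds shown here alone, whether an amine or methoxy on this aromatic carbon would keep the read-out at this level remains open. So does whether the third chlorine would behave alike on a core other than that of compound 1.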